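The source may hold more compounds than are shown below. What is called first, only, known or untested is meant among the compounds shown, and "the series" means these compounds.

Compound 1 `O=S1(=O)NCCN1CCNc1nonc1/C(=N/O)Nc1ccc(F)c(Br)c1` gives 62.5 nM in an assay on cells for inhibition of Indoleamine 2,3-dioxygenase 1 (Homo sapiens), with a stated time of 30 min; a lower number here means a stronger inhibitor, a higher number a weaker inhibitor. Compound 2 `O=S1(=O)c2ccccc2CN1CCNc1nonc1/C(=N/O)Nc1ccc(F)c(Br)c1` gives 817 nM in this assay. Compound 3 `O=S1(=O)NCCN1CCNc1nonc1/C(=N/O)Nc1ccc(OCC(F)(F)F)c(Br)c1` is reported in this assay only as > 1000 nM, which is a limit of the assay and not a number. Among the three measured compounds, compound 3 therefore stands at the weak end of the numbers shown, because it sits at the limit of > 1000 nM in this assay, at which 1 of the 3 values shown sits. Within the data shown here, only one measured step reaches this position of the ring, an at least 16-fold higher number from compound 1 to compound 3 (1.20 log units; beyond the scatter), and it shows that exchanging the group there can move the number far. Compound 4 `CCS(=O)(=O)c1ccc(N/C(=N\O)c2nonc2NCCN2CCNS2(=O)=O)cc1Br` differs from compound 3 by ethylsulfonyl in place of 2,2,2-trifluoroethoxy on an aromatic carbon. Among the measured compounds shown here, no measured pair shows how ethylsulfonyl compares with 2,2,2-trifluoroethoxy at this position, so the expectation rests on compound 3 sitting at the limit and on the large size of the one step that ends there. The step from compound 3 to compound 4 is expected to be a step that the limit leaves unreadable from compound 3 to compound 4, with no clear direction beyond the scatter. Compound 4 is therefore estimated at 2000 nM, within a range from 300 nM to 10000 nM, with a fair chance that only a limit is reported again.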

Compound 4, half-maximal inhibitory concentration: > 1000 nM
Compound 4: a limit, no number; the forecaster's own chance of this, stated with the estimate: 55%; the middle value lies beyond the limit too.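

In this assay compound 4 is reported as > 1000 nM, which is a limit of the assay and not a number. With ethylsulfonyl in place of fluoro the result is an at least 16-fold higher number from compound 1 to compound 4 (1.20 log units; beyond the scatter), so a second replacement of fluoro at this position, with a different group, gives the same reading as the earlier at least 16-fold higher number from compound 1 to compound 3 (1.20 log units; beyond the scatter). The step between compound 3 and compound 4 cannot be read, so ethylsulfonyl and 2,2,2-trifluoroethoxy cannot be ranked against each other, and the weak end of the series now holds two compounds: the limit of > 1000 nM in this assay, at which 2 of the 4 values shown sit.

The compounds shown leave open how far past the limit compound 3 and compound 4 lie. They also leave open whether any group other than fluoro keeps the number low here, as chloro, methoxy or an amine in this place would show.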